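A Second Hydroxy on the Ring of Compound 3

A few compounds are considered here, and "the series" means these few. Any claim that something is new, unique, unknown or untested is made for them only; others in the source may bear on it.

Compound 1 `CN(C)c1ccc(/C=C/C=C/C(=O)N2CCCCC2)cc1` in an assay for inhibition of Polyunsaturated fatty acid 5-lipoxygenase (Homo sapiens), read by spectrophotometry, tested at 20 uM; a lower number here means less inhibition, a higher number more inhibition at the concentration tested (going by the name of the read-out): compound 1 gives 13.4%
Compound 2 `O=C(/C=C/C=C/c1ccc(Cl)cc1)N1CCCCC1`: compound 2 gives 14.5%
Compound 3 `O=C(/C=C/C=C/c1ccc(O)cc1)N1CCCCC1`: compound 3 gives 44.4%

Going by the values given here, all three share one core and differ only in the single group on the aromatic ring. Compound 3 stands highest of the three numbers: the nearest is compound 2, with a rise of a number 29.9 percentage points higher from compound 2 to compound 3 (beyond the scatter), and the furthest is compound 1, with a rise of a number 31 percentage points higher from compound 1 to compound 3 (beyond the scatter). The exchange of dimethylamino for chloro, a number 1.1 percentage points higher from compound 1 to compound 2 (within the scatter), changed nothing beyond the scatter, so the hydroxy group alone sets compound 3 apart.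

Compound 4 `O=C(/C=C/C=C/c1ccc(O)c(O)c1)N1CCCCC1` carries the change (hydroxy in place of hydrogen on an aromatic carbon). Among the compounds with values here, no measured pair shows a second hydroxy entering, so the only guidance is the two steps in which one hydroxy entered and inhibition rose. On that basis a further rise is expected, though a smaller one than before is the cautious reading: the expected step is a number 15.6 percentage points higher from compound 3 to compound 4 (beyond the scatter). For compound 4 the estimate in this assay is 60%, within 40% to 80%.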

Compound 4, a percentage reported as inhibition, at one concentration (the size of the read-out at that concentration, not a potency): 82.8%
The estimate for compound 4 lay 22.8 percentage points below the measured number; measured number outside the range, above it.
By their numbers in this assay, from the lowest: compounds 1 and 2 (each within the scatter of the next); then compound 3; then compound 4.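

In this assay the step of a number 38.4 percentage points higher from compound 3 to compound 4 (beyond the scatter) comes from one hydroxy taking the place of a hydrogen, on a ring that already carries a hydroxy. Going by these compounds alone, the earlier compounds varied only the one group already on the ring, whereas this result shows that a second ring position, ortho to a hydroxy group and meta to a large group, also strongly affects the inhibition read at this concentration. No measurement at hand explains why this change has such an effect.

As far as these compounds go, what stays open is whether the rise is specific to a hydroxy at this position, or whether a methoxy group, an amine or a fluorine there would also raise the number. Also open, from the compounds shown here alone, is whether a hydroxy at this position would give a similar rise with hydrogen in place of the first hydroxy.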